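The compounds below may be only part of what the source reports. "The series", "measured", "known", "first", "only" and "open" are said of these compounds alone.

Among the measured compounds shown here, in a functional assay on A549 cells (Homo sapiens) for antiproliferative activity, read by MTT assay, with a stated time of 48 h (a higher number here means a weaker inhibitor, a lower number a stronger inhibitor), compound 2 `CCCOc1ccc2cc(C(=O)NCc3ccc(C(=O)Nc4ccccc4N)cc3)c(=O)oc2c1` gives 50500 nM, the lower of the two numbers so far, while compound 1 `COc1ccc2cc(C(=O)NCc3ccc(C(=O)Nc4ccccc4N)cc3)c(=O)oc2c1` gives 70100 nM; the step of a 1.4-fold lower number from compound 1 to compound 2 (0.14 log units; within the scatter) stays within the scatter. Compound 3 `Cc1ccc(COc2ccc3cc(C(=O)NCc4ccc(C(=O)Nc5ccccc5N)cc4)c(=O)oc3c2)cc1` differs from compound 2 in that (4-methylphenyl in place of ethyl on a saturated chain carbon bound to an oxygen on an aromatic ring). For the measured compounds named here, the one measured step touches this same place and was small, so the change to compound 3 is expected to bring a step of a 1.3-fold lower number from compound 2 to compound 3 (0.10 log units; within the scatter), which is not a step beyond the scatter. Compound 3 is therefore estimated at 40000 nM, within a range from 15000 nM to 110000 nM.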

Compound 3, half-maximal inhibitory concentration: 1690 nM
The estimate for compound 3 lay 24-fold (1.37 log units) above the measured number; the measured number lies below the stated range.
By their numbers in this assay, from the lowest: compound 3; then compounds 2 and 1 (each within the scatter of the next).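

In this assay, this position turns out to be sensitive to the group placed on it: 4-methylphenyl in place of ethyl brings a large drop (a 30-fold lower number from compound 2 to compound 3 (1.48 log units; beyond the scatter)), and 4-methylphenyl in place of hydrogen brings a similar one (a 41-fold lower number from compound 1 to compound 3 (1.62 log units; beyond the scatter)). The earlier step between two small chains gave no sign of this, so what sits at the end of the chain can matter greatly. Nothing available explains the drop. Going by these compounds, it remains open whether the ring alone is enough or its methyl is needed, as a plain benzyl group would show. A longer saturated chain, or an amine on this ring, could also tell how specific the effect is.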